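Aryl Group Swap on the Shared Core: Predicting Compound 4

The source may hold more compounds than are shown below. What is called first, only, known or untested is meant among the compounds shown, and "the series" means these compounds.

Measured so far:
compound 1, `CCc1ccc(Nc2cc(NC(=O)Nc3cc(OC)cc(OC)c3)ncn2)cc1`: 66.2%
compound 2, `COc1cc(NC(=O)Nc2cc(Nc3ccc(OC)c(C)c3)ncn2)cc(OC)c1`: 48.3%
compound 3, `COc1cc(NC(=O)Nc2cc(Nc3ccc(OC)c(I)c3)ncn2)cc(OC)c1`: 61.7%

In a functional assay on HCC827 cells (Homo sapiens) for inhibition, read by MTT assay, with a stated time of 48 h, tested at 10 uM (on this read-out higher numbers stand for more inhibition at the one concentration tested (going by the name of the read-out) and lower numbers for less inhibition), compound 3 stands second highest of the three numbers; compound 1 gives 66.2%, within the scatter of it, while the other step, a number 13.4 percentage points higher from compound 2 to compound 3 (beyond the scatter), lies beyond it. Compound 4, `COc1cc(NC(=O)Nc2cc(Nc3cc(C)cc(F)c3)ncn2)cc(OC)c1`, is not yet measured and differs from compound 3 by 3-fluoro-5-methylphenyl in place of 3-iodo-4-methoxyphenyl on a nitrogen on an aromatic ring. Two earlier steps changed the same aryl group: a number 4.5 percentage points lower from compound 1 to compound 3 (within the scatter) and a number 13.4 percentage points higher from compound 2 to compound 3 (beyond the scatter). Because a number 13.4 percentage points higher from compound 2 to compound 3 (beyond the scatter) showed the iodo version ahead of the methyl version, the entering 3-fluoro-5-methylphenyl, which carries methyl rather than iodo, is expected to bring a modest loss. The step is expected to be a number 7.7 percentage points lower from compound 3 to compound 4 (within the scatter). Compound 4 is therefore estimated at 54%, between 38% and 70%.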

Compound 4, a percentage reported as inhibition, at one concentration (the size of the read-out at that concentration, not a potency): 62.1%
For compound 4 the middle estimate is 8.1 percentage points below the measured one; the measured number falls inside the stated range.
By their numbers in this assay, from the lowest: compound 2; then compounds 3, 4 and 1 (each within the scatter of the next).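

In this assay the 3-fluoro-5-methylphenyl group on this nitrogen holds up without a methoxy or an iodo: there is a number 0.4 percentage points higher from compound 3 to compound 4 (within the scatter) and a number 4.1 percentage points lower from compound 1 to compound 4 (within the scatter). The other step is a number 13.8 percentage points higher from compound 2 to compound 4 (beyond the scatter), so a methyl on this ring does not by itself go with the lowest number. No measurement given here explains these steps. From the compounds shown here alone, the separate shares of the fluoro and the methyl stay open, since neither changes alone. Going by these compounds, what an amine or a carboxylic acid on this ring would do also stays open.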